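This account rests on a few compounds, and the source may have more. Where it says the series, first, only, none or still open, it means among the compounds named here.

Compound 1 `Cc1cc(Nc2nc(NCc3ccc(F)cc3)nc3ccccc23)n[nH]1` is the reference point of this pair. For the measured compounds named here, in an assay for inhibition of high affinity nerve growth factor receptor (Homo sapiens), read by HTRF, with a stated time of 30 min, in the presence of a further agent that is not named here (on this read-out higher numbers stand for weaker inhibition and lower numbers for stronger inhibition), compound 1 gives 20 nM, the lowest of the two numbers measured so far; its nearest neighbour is compound 2 `Cc1cc(Nc2nc(NCc3ccc(Cl)cc3)nc3ccccc23)n[nH]1`, which in this assay gives 380 nM. Going by the values given here, the single measured step, chloro in place of fluoro on an aromatic carbon, reads a 19-fold higher number from compound 1 to compound 2 (1.28 log units; beyond the scatter). Compound 3 `Cc1cc(Nc2nc(NCc3ccc(Br)cc3)nc3ccccc23)n[nH]1` carries the change (bromo in place of fluoro on an aromatic carbon), bromo in place of fluoro on an aromatic carbon of a six-membered aromatic ring of carbon only, para to a large group. Among the compounds with values here, the only step that bears on it is the one from compound 1 to compound 2, which was large and toward a higher number; the bromo change is expected to move in the same direction, its size uncertain. The expected step is a 25-fold higher number from compound 1 to compound 3 (1.40 log units; beyond the scatter). Compound 3 is therefore expected to give about 500 nM in this assay, within a range from 100 nM to 2500 nM.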

Compound 3, half-maximal inhibitory concentration: 180 nM
Estimate against measurement, compound 3: 2.8-fold (0.44 log units) above; measured number inside the range.
By their numbers in this assay, from the lowest: compound 1; then compound 3; then compound 2.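

With bromo as a second replacement on the 4-fluorobenzyl group, in this assay, the loss on leaving fluoro is no longer tied to chloro alone: the change reads a 9.0-fold higher number from compound 1 to compound 3 (0.95 log units; beyond the scatter). The three halogens do not give a steady climb in the order fluoro, chloro, bromo, since the change from chloro to bromo reads a 2.1-fold lower number from compound 2 to compound 3 (0.32 log units; beyond the scatter), so compound 3 goes against any such trend and falls between compound 1 and compound 2. Nothing available accounts for this order.

Whether fluoro's lead reflects something particular to fluorine or whether non-halogen groups could match it remains open, as the compounds shown hold only halogens at this place. A methoxy, a nitrile, a trifluoromethyl or plain hydrogen there would test this.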